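The compounds below may be only part of what the source reports. "The series", "measured", "known", "first", "only" and "open" are said of these compounds alone.

Among the compounds with values here, in an in vitro ADME assay on microsomes from liver (Homo sapiens) for metabolic stability, tested at 5 uM (a higher number here means that the compound lasts longer, a lower number that the compound disappears faster), compound 2 `CS(=O)(=O)Nc1ccc2c(c1)S(=O)(=O)N=C(c1c(O)c(-c3cccs3)nn(CC3(C(F)(F)F)CCC3)c1=O)N2` gives 1 h, the only exact number available. Compound 1 `CCC(C)(C)Cn1nc(-c2cccs2)c(O)c(C2=NS(=O)(=O)c3cc(NS(C)(=O)=O)ccc3N2)c1=O` gives > 1 h, which is a limit of the assay. Within the data shown here, the one measured step, a number no higher from compound 1 to compound 2 (the limit leaves the size open), changes the same side chain, but its size stays open and so sets no scale. Compound 3 `CS(=O)(=O)Nc1ccc2c(c1)S(=O)(=O)N=C(c1c(O)c(-c3cccs3)nn(CCC3CCC3)c1=O)N2` differs from compound 2 by cyclobutylmethyl in place of 1-(trifluoromethyl)cyclobutyl on a saturated chain carbon bound to an aromatic nitrogen: cyclobutylmethyl replaces 1-(trifluoromethyl)cyclobutyl. No size can be carried over, so the expected step, a 1.3-fold lower number from compound 2 to compound 3 (0.10 log units; within the scatter), stays within the scatter. For compound 3, the estimated half-life is 0.8 h, with an expected range of 0.35 h to 1.6 h.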

Compound 3, half-life: > 1 h
Compound 3 ended at the assay's limit; the forecaster's own chance of this, stated with the estimate: 30%; middle value at least 1.2-fold (0.09 log units) from the limit.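

Replacing 1-(trifluoromethyl)cyclobutyl with cyclobutylmethyl on a saturated chain carbon bound to an aromatic nitrogen gives a number no lower from compound 2 to compound 3 (the limit leaves the size open) in this assay, so at this position a side chain without fluorine shows no loss of half-life. The value of compound 3, > 1 h, is a limit. The step between compound 1 and compound 3 cannot be read, and no step here has a readable size: the limit of > 1 h in this assay, at which 2 of the 3 values shown sit.

From the compounds shown here alone, how far compound 1 and compound 3 lie past that limit remains open, so their side chains cannot be ranked. Also open, going by these compounds, is how an amine or a longer carbon chain would behave at this position.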